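The source may report more compounds than this note shows. Statements on the series, on what has been measured and on what is new or still open speak of the compounds shown alone.

Compound 1: `CC1=C(C(=O)SC(C)C)C(c2ccoc2)NC(=O)N1` — 637 nM
Compound 2: `CC1=C(c2ncc(C)o2)C(c2ccoc2)NC(=O)N1` — 801 nM
Compound 3: `CCC(C)OC(=O)C1=C(C)NC(=O)NC1c1ccco1` — 84.3 nM

All three compounds were tested in an assay on membranes from HEK293 cells for displacement of a labelled ligand from adenosine receptor A2b (Homo sapiens), read by scintillation counting, with a stated time of 30 min; a lower number here means a stronger inhibitor, a higher number a weaker inhibitor. Among these three numbers compound 1, with 637 nM, stands second highest. Its nearest neighbour is compound 2: the step of a 1.3-fold higher number from compound 1 to compound 2 (0.10 log units; within the scatter) lies within the usual scatter, so the two cannot be ranked against each other. The furthest number belongs to compound 3, whose 84.3 nM is markedly lower, a gap that lies beyond the scatter; compound 3 differs from compound 1 in more than one place, so no single step can be read from that pair.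

Compound 4 is `CC1=C(C(=O)OCC2CCC2)C(c2ccoc2)NC(=O)N1`. It differs from compound 1 in one place: cyclobutylmethoxy in place of isopropylsulfanyl on a carbonyl carbon. For the measured compounds named here, the one measured step on this part of the core, the replacement of the whole (isopropylsulfanyl)carbonyl group by an oxazole on the way from compound 1 to compound 2, barely moved the number. The change to compound 4 keeps the carbonyl carbon and swaps only what hangs on it, and the lower number of compound 3, which also carries an oxygen-linked group on its carbonyl, hints that such a group is tolerated or better. Compound 4 is therefore expected to give a somewhat lower number, with the step of a 2.0-fold lower number from compound 1 to compound 4 (0.30 log units; within the scatter) as the estimate, though it might equally stay within the scatter of compound 1. The estimate for compound 4 is 320 nM, with a range from 90 nM to 1200 nM.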

Compound 4, inhibition constant: 739 nM
For compound 4 the middle estimate is 2.3-fold (0.36 log units) below the measured one, within the range that was stated.
By their numbers in this assay, from the lowest: compound 3; then compounds 1, 4 and 2 (each within the scatter of the next).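

In this assay, cyclobutylmethoxy in place of isopropylsulfanyl on a carbonyl carbon gives a 1.2-fold higher number from compound 1 to compound 4 (0.06 log units; within the scatter) and the two compounds cannot be told apart. The earlier step replaced the whole (isopropylsulfanyl)carbonyl group, whereas this one keeps the carbonyl and changes only what hangs on it, from a sulfur-linked group without a ring to a larger oxygen-linked group carrying a four-membered carbon ring, and this exchange alone does not give a number beyond the scatter of compound 1. No measurement shown here offers an explanation for this result.

Going by these compounds, whether a much smaller group on the carbonyl carbon, such as methoxy, or an amine in the same place would separate from compound 1 remains open. Compound 3 has a clearly lower number than compound 1 but differs from it in more than one place, so the compounds shown cannot say which of its differences accounts for that gap.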